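The source may hold more compounds than are shown below. What is called first, only, known or untested is meant among the compounds shown, and "the series" means these compounds.

Compound 1 `COc1cc(C(=O)/C(C#N)=C/c2ccc(OC)c(OC)c2OC)cc(OC)c1OC` is one of three closely related compounds tested in an ADME assay on K562 cells (Homo sapiens) for cytotoxicity, read by MTT assay, with a stated time of 5 days; on this read-out higher numbers stand for weaker inhibition and lower numbers for stronger inhibition. In this assay compound 1 gives > 10000 nM, which is a limit of the assay rather than a number. Compound 2 `COc1ccc(/C=C(\C#N)C(=O)c2cc(OC)c(OC)c(OC)c2)c(F)c1` gives > 10000 nM in this assay, again a limit. Compound 3 `COc1ccc(/C=C(\C#N)C(=O)c2cc(OC)c(OC)c(OC)c2)cc1Br` gives > 10000 nM, also a limit. Among the measured compounds shown here, the only step between measured neighbours, a step that the two limits leave unreadable from compound 2 to compound 3, therefore cannot be sized, and the sole piece of evidence is the limit of > 10000 nM in this assay, at which 3 of the 3 values shown sit. Compound 4 `COc1cc(C(=O)/C(F)=C/c2ccc(OC)c(OC)c2OC)cc(OC)c1OC` differs from compound 1 by fluoro in place of cyano on a double-bonded chain carbon bound to a carbonyl carbon and a double-bonded chain carbon. For the measured compounds named here, no measured step bears on this change. The estimate for compound 4 is 15000 nM, between 4000 nM and 60000 nM, a step that the limit leaves unreadable from compound 1 to compound 4 expected because compound 1 already sits at > 10000 nM.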

Compound 4, half-maximal inhibitory concentration: 10000 nM
For compound 4 the middle estimate is 1.5-fold (0.18 log units) above the measured one, and the stated range covers the measured number.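

In this assay compound 4 gives 10000 nM, the only actual number among the compounds shown rather than a limit. Fluoro in place of cyano at this carbon gives a number no higher from compound 1 to compound 4 (the limit leaves the size open), so this position now has one readable value, but the size of the change stays unknown. The set as a whole still sits mostly at the edge of what the measurement can read: the limit of > 10000 nM in this assay, at which 3 of the 4 values shown sit.

The compounds shown leave open how other groups at this carbon, such as an amine or a carboxylic acid, would read in this assay. They also leave open whether fluoro in place of cyano would give a readable number on compound 2 or compound 3.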